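The compounds below may be only part of what the source reports. "The series", "measured", "known", "first", "only" and "open" are said of these compounds alone.

Of the compounds shown here, three have been measured in a physicochemical assay for lipophilicity, read by HPLC, measured as chromatographic lipophilicity, at pH 7.4; on this read-out lower numbers stand for lower lipophilicity and higher numbers for higher lipophilicity. Compound 1 `CC[C@H]1OC(=O)[C@H](C)[C@@H](O[C@H]2C[C@@](C)(OC)[C@@H](O)[C@H](C)O2)[C@H](C)[C@@H](O[C@@H]2O[C@H](C)C[C@H](N(C)C)[C@H]2O)[C@](C)(O)C[C@@H](C)CN(C)[C@H](C)[C@@H](OCCCNC(=O)c2c(C)nn(C)c2Cl)[C@]1(C)O` gives 3.01 in this assay. Compound 2 `CCC(=O)NCCCO[C@@H]1[C@@H](C)N(C)C[C@H](C)C[C@@](C)(O)[C@H](O[C@@H]2O[C@H](C)C[C@H](N(C)C)[C@H]2O)[C@@H](C)[C@H](O[C@H]2C[C@@](C)(OC)[C@@H](O)[C@H](C)O2)[C@@H](C)C(=O)O[C@H](CC)[C@@]1(C)O` gives 2.74. Compound 3 `CCC(=O)NCCCO[C@H]1[C@H](O[C@@H]2[C@@H](C)[C@H](O[C@H]3C[C@@](C)(OC)[C@@H](O)[C@H](C)O3)[C@@H](C)C(=O)O[C@H](CC)[C@@](C)(O)[C@H](O)[C@@H](C)N(C)C[C@H](C)C[C@@]2(C)O)O[C@H](C)C[C@@H]1N(C)C` is built from the same atoms as compound 2, joined differently; the difference between the two cores is not broken down here. In this assay compound 3 gives 2.7. Compound 4 `CC[C@H]1OC(=O)[C@H](C)[C@@H](O[C@H]2C[C@@](C)(OC)[C@@H](O)[C@H](C)O2)[C@H](C)[C@@H](O[C@@H]2O[C@H](C)C[C@H](N(C)C)[C@H]2OCCCNC(=O)c2c(C)nn(C)c2Cl)[C@](C)(O)C[C@@H](C)CN(C)[C@H](C)[C@@H](O)[C@]1(C)O` has not yet been measured.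

Compound 2 and compound 1 differ in one place: 5-chloro-1,3-dimethyl-1H-pyrazol-4-yl in place of ethyl on a carbonyl carbon. The step is a number 0.27 log units higher from compound 2 to compound 1 (within the scatter). Compound 4 stands to compound 3 as compound 1 stands to compound 2: 5-chloro-1,3-dimethyl-1H-pyrazol-4-yl in place of ethyl on a carbonyl carbon. The place is described in the same words for both pairs, so it is the same change, made on the core of compound 3 instead of the core of compound 2. Among the measured compounds shown here, its size has been seen only once, in the pair of compound 2 and compound 1, so there is no second measured pair to show how much it varies from one core to another.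

For the measured compounds named here, for compound 4 the step from compound 3 is expected to be a number 0.27 log units higher from compound 3 to compound 4 (within the scatter), close to the step seen before, because a number 0.27 log units higher from compound 2 to compound 1 (within the scatter) is the only measured example of this change. Compound 4 is therefore estimated at 2.97 in this assay, expected to fall between 2.6 and 3.35.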

Compound 4, distribution coefficient: 3.08
Estimate against measurement, compound 4: 0.11 log units below, within the range that was stated.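

In this assay, putting 5-chloro-1,3-dimethyl-1H-pyrazol-4-yl in place of ethyl on the carbonyl carbon gives a number 0.38 log units higher from compound 3 to compound 4 (beyond the scatter) and, on the other core, gave a number 0.27 log units higher from compound 2 to compound 1 (within the scatter) so the change points the same way in both pairs, although only the new step lies beyond the usual scatter. This gives modest support for carrying the change between these two cores, but two pairs cannot show how much its size varies from core to core or whether the same direction would hold on any further core. Nothing measured here explains why the step takes the size it does.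

The compounds shown leave open how the step would read with other groups on the same carbonyl carbon, such as a phenyl group, a dimethylaminomethyl group or a longer chain than ethyl. They also leave open how much of the step belongs to the chlorine, a question that the same ring carrying a hydrogen in its place could begin to answer on both cores.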